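The source may report more compounds than this note shows. Statements on the series, on what has been measured and on what is new or still open speak of the compounds shown alone.

Measured compounds: compound 1 `NS(=O)(=O)Oc1ccc2c(c1)CN(C(=O)c1ccc(N(Cc3ccccc3)Cc3ccco3)cc1)CC2` with 90.8% and compound 2 `CCN(Cc1ccccc1)c1ccc(C(=O)N2CCc3ccc(OS(N)(=O)=O)cc3C2)cc1` with 66.9% in an assay on HEK293 cells for inhibition of Steryl-sulfatase (Homo sapiens), tested at 0.1 uM; on this read-out higher numbers stand for a stronger effect at the one concentration tested and lower numbers for a weaker effect.

Compound 2 stands lowest of the two numbers, with compound 1 the nearest and higher by a number 23.9 percentage points lower from compound 1 to compound 2 (beyond the scatter). Compound 3 `NS(=O)(=O)Oc1ccc2c(c1)CN(C(=O)c1ccc(N(CCCO)Cc3ccccc3)cc1)CC2` differs from compound 2 by hydroxymethyl in place of hydrogen on a saturated chain carbon, two bonds along the chain from a nitrogen on an aromatic ring. Going by the values given here, the only measured step, from compound 1 to compound 2, alters the group on the same nitrogen but is a different change, so it bears on this step only loosely. For compound 3 the step of a number 3.1 percentage points higher from compound 2 to compound 3 (within the scatter) is therefore expected to stay within the scatter, and compound 3 is estimated at 70% with a range from 50% to 88%.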

Compound 3, a percentage reported as inhibition, at one concentration (the size of the read-out at that concentration, not a potency): 5.7%
For compound 3 the middle estimate is 64.3 percentage points above the measured one; the whole stated range lies above it.
By their numbers in this assay, from the lowest: compound 3; then compound 2; then compound 1.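

The change of ethyl to 3-hydroxypropyl gives a number 61.2 percentage points lower from compound 2 to compound 3 (beyond the scatter) in this assay, so a small addition on this saturated chain carbon can remove nearly all of the effect at the one concentration tested. Set against a number 85.1 percentage points lower from compound 1 to compound 3 (beyond the scatter), this shows that the group on this nitrogen can shift the read-out much further than the earlier step from furan-2-yl to methyl suggested. Nothing measured here accounts for the loss. The compounds shown leave open whether it follows the hydroxyl or the longer chain. A plain propyl group or a 3-aminopropyl group in place of 3-hydroxypropyl would bear on that question.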